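Pendant aryl variation in a tricyclic chromone series

The source may hold more compounds than are shown below. What is called first, only, known or untested is meant among the compounds shown, and "the series" means these compounds.

Measured so far:
compound 1 `CCC1=C(O)c2c(oc(-c3ccc(CC(C)C)cc3)cc2=O)C(CC)(CC)C1=O` — 17.4 uM
compound 2 `CCC1=C(O)c2c(oc(-c3ccc(COC)cc3)cc2=O)C(CC)(CC)C1=O` — 3.4 uM

Both compounds were run in a functional assay on KBVIN cells (Homo sapiens) for antiproliferative activity, read by sulforhodamine B assay, with a stated time of 3 days; a lower number here means that less compound is needed, a higher number that more compound is needed for the effect. Compound 1 gives 17.4 uM and compound 2 gives 3.4 uM. Within the data shown here, the one step measured within the pair, a 5.1-fold lower number from compound 1 to compound 2 (0.71 log units; beyond the scatter), is a modest step beyond the scatter. Among the measured compounds shown here, compound 2 therefore stands at the lowest of the two numbers, with compound 1 as its only neighbour.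

The next compound, compound 3 `CCC1=C(O)c2c(oc(-c3ccc(O)c(C)c3C)cc2=O)C(CC)(CC)C1=O`, has not yet been run in this assay. It differs from compound 2 as follows: 4-hydroxy-2,3-dimethylphenyl in place of 4-(methoxymethyl)phenyl on an aromatic carbon. The change sits on an aromatic carbon of the shared core, next to the ring oxygen and para to a fused ring.

For the measured compounds named here, only the step from compound 1 to compound 2 bears on this, and only loosely: it also rewrote the group on the pendant phenyl, and gave a modest step, a 5.1-fold lower number from compound 1 to compound 2 (0.71 log units; beyond the scatter). Nothing measured here speaks directly to a 4-hydroxy-2,3-dimethylphenyl, so the expectation is weak. Compound 3 is expected to give 6 uM (range 2 uM to 20 uM), an estimated step of a 1.8-fold higher number from compound 2 to compound 3 (0.25 log units; within the scatter) from compound 2, which may fall within the scatter.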

Compound 3, concentration for half-maximal effect: 2.75 uM
Compound 3: middle estimate off by 2.2-fold (0.34 log units), on the high side; the measured number falls inside the stated range.
By their numbers in this assay, from the lowest: compounds 3 and 2 (each within the scatter of the next); then compound 1.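

In this assay, 4-hydroxy-2,3-dimethylphenyl in place of 4-(methoxymethyl)phenyl on the aromatic carbon next to the ring oxygen gives a 1.2-fold lower number from compound 2 to compound 3 (0.09 log units; within the scatter), so this position tolerates a rewrite of the whole substitution pattern on the pendant phenyl, whereas the earlier pair showed only a change of one chain group. The two groups match in heavy atoms and ring type, but the entering group has a hydrogen-bond donor and the leaving group has none, and in this one pair that difference in donor count comes with no change beyond the scatter. No independent measurement is available to explain why compound 2 and compound 3 fall within the scatter of each other.

The hydroxy group and the two methyl groups enter together, so the compounds shown cannot separate their individual contributions, and a matching or opposing effect among them remains possible. Also open, from the compounds shown here alone, is whether the same tolerance would hold for a pendant phenyl carrying an amine or a carboxylic acid in place of the hydroxy group.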